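Hydroxydimethylcyclohexyl in Place of the Methylcarbamoyl Ring

This account rests on a few compounds, and the source may have more. Where it says the series, first, only, none or still open, it means among the compounds named here.

Compound 1 `CO[C@H]1CC[C@H](Nc2cc(NCc3cnccc3C(F)(F)F)ncc2C#N)CC1`: in an assay on isolated protein for inhibition of protein kinase C theta type (Homo sapiens), read by TR-FRET, with a stated time of 2 h (on this read-out lower numbers stand for stronger inhibition and higher numbers for weaker inhibition), compound 1 gives 1100 nM.
Compound 2 `N#Cc1cnc(NCc2cnccc2C(F)(F)F)cc1NC1CCOCC1`: in this assay compound 2 gives 900 nM.
Compound 3 `CNC(=O)[C@H]1CC[C@@H](Nc2cc(NCc3cnccc3C(F)(F)F)ncc2C#N)CC1`: in this assay compound 3 gives 27 nM.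

Compound 3 holds the lowest number of the three, and both steps toward it are beyond the scatter: a 41-fold lower number from compound 1 to compound 3 (1.61 log units; beyond the scatter) and a 33-fold lower number from compound 2 to compound 3 (1.52 log units; beyond the scatter). By contrast, a 1.2-fold lower number from compound 1 to compound 2 (0.09 log units; within the scatter), so the 4-methoxycyclohexyl and oxan-4-yl groups cannot be told apart on these numbers.

Compound 4 `CC1(C)C[C@@H](Nc2cc(NCc3cnccc3C(F)(F)F)ncc2C#N)CC[C@@H]1O` has not yet been measured. It differs from compound 3 in one place: 4-hydroxy-3,3-dimethylcyclohexyl in place of 4-(methylcarbamoyl)cyclohexyl on a nitrogen on an aromatic ring. The two large steps bear directly on this change, since each shows that the methylcarbamoyl ring of compound 3 sets it apart from compounds 1 and 2, and compound 4 gives up that ring. What enters carries a hydroxyl in place of the amide, with two methyl groups on the ring; this lies nearer to the 4-methoxycyclohexyl of compound 1 than to the group of compound 3, though it is not the same. A step upward in this assay from compound 3 to compound 4 is therefore expected, likely beyond the scatter, but the hydroxyl leaves room for compound 4 to stop short of compounds 1 and 2, so the expected step is a 7.4-fold higher number from compound 3 to compound 4 (0.87 log units; beyond the scatter). Compound 4 is estimated at 200 nM, with a range from 40 nM to 1000 nM.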

Compound 4, half-maximal inhibitory concentration: 120 nM
Compound 4: middle estimate off by 1.7-fold (0.22 log units), on the high side; low and high end bracket the measured number.
By their numbers in this assay, from the lowest: compound 3; then compound 4; then compounds 2 and 1 (each within the scatter of the next).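

In this assay, among these compounds, the methylcarbamoyl group is not the only way to a number clearly lower than those of compounds 1 and 2 at this place, on a nitrogen on an aromatic ring: the amide-free 4-hydroxy-3,3-dimethylcyclohexyl gives a 7.5-fold lower number from compound 2 to compound 4 (0.88 log units; beyond the scatter) and a 9.2-fold lower number from compound 1 to compound 4 (0.96 log units; beyond the scatter) on the same core. It does not fully replace 4-(methylcarbamoyl)cyclohexyl, however, with a 4.4-fold higher number from compound 3 to compound 4 (0.65 log units; beyond the scatter) on this exchange, so the earlier gap between compound 3 and compounds 1 and 2 now has compound 4 standing inside it, and the position gives a graded series rather than a plain split. No measurement in hand gives a reason for any of these steps.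

On these data alone, what remains open is whether the hydroxyl or the two methyl groups account for the step from compound 1 to compound 4, as the two groups change together in this comparison; a plain 4-hydroxycyclohexyl would separate them. As far as these compounds go, it is also open how a 4-aminocyclohexyl or a 4-carboxycyclohexyl on the same nitrogen would compare with compound 3 and compound 4.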